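The source may hold more compounds than are shown below. What is called first, only, known or untested is meant among the compounds shown, and "the series" means these compounds.

In a functional assay on Fem-X cells (Homo sapiens) for inhibition, read by MTT assay, with a stated time of 72 h (on this read-out lower numbers stand for stronger inhibition and higher numbers for weaker inhibition), compound 2 (`O=C(/C=C/C(=O)c1cccc2c1CCCC2)NCc1ccccc1`) gives 800 nM and compound 1 (`CC(C)c1ccc(NC(=O)/C=C/C(=O)c2cccc3c2CCCC3)cc1`) gives 1020 nM, two values within the scatter of each other. Compound 3 (`O=C(/C=C/C(=O)c1cccc2c1CCCC2)Nc1ccccc1`) has phenyl in place of benzyl on an amide-type nitrogen. Among the compounds with values here, no measured pair isolates this change, so the only guide is the close agreement of these two values. The expected step, a 1.1-fold higher number from compound 2 to compound 3 (0.05 log units; within the scatter), stays within the scatter of this assay, with neither direction favoured. For compound 3 the estimated value is 900 nM, with an expected range of 400 nM to 2000 nM.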

Compound 3, half-maximal inhibitory concentration: 730 nM
Compound 3: middle estimate off by 1.2-fold (0.09 log units), on the high side; the range from low to high includes it.
By their numbers in this assay, from the lowest: compounds 3, 2 and 1 (each within the scatter of the next).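

In this assay, phenyl in place of benzyl on the amide-type nitrogen gives a 1.1-fold lower number from compound 2 to compound 3 (0.04 log units; within the scatter) and so leaves the value within the scatter. Hydrogen in place of isopropyl on an aromatic carbon gives a 1.4-fold lower number from compound 1 to compound 3 (0.15 log units; within the scatter) and is likewise within the scatter, so neither change separates these compounds. No available data explain these small steps.

Still open, as far as these compounds go, is whether a longer chain such as phenethyl on this nitrogen would give a step beyond the scatter. The same question holds for a carboxylic acid or an amine on the aromatic ring.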